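Acetylating the hydroxy group of compound 1

The source may report more compounds than this note shows. Statements on the series, on what has been measured and on what is new or still open speak of the compounds shown alone.

Measured in a functional assay on WHCO1 cells (Homo sapiens) for cytotoxicity, read by MTT assay, with a stated time of 24 h; on this read-out higher numbers stand for weaker inhibition and lower numbers for stronger inhibition:
- compound 1 `CC(=O)O[C@@H]1[C@@H](OC(C)=O)C(C)=C(CC/C(C)=C/CO)[C@@]2(C)CCCC(C)(C)[C@H]12`: 25000 nM
- compound 2 `CC(=O)O[C@H]1CC(C)(C)[C@@H]2[C@H](OC(C)=O)[C@@H](OC(C)=O)C(C)=C(CC/C(C)=C/CO)[C@@]2(C)C1`: 24000 nM

Going by the values given here, compound 1 gives 25000 nM and stands within the scatter of compound 2, the only other compound measured. Compound 3 `CC(=O)OC/C=C(\C)CCC1=C(C)[C@H](OC(C)=O)[C@@H](OC(C)=O)[C@H]2C(C)(C)CCC[C@]12C` is still unmeasured. It keeps the core of compound 1 and turns hydroxy to acetoxy: acetyl in place of hydrogen on an oxygen on a saturated carbon. Among the compounds with values here, only one measured step offers a guide, and only an indirect one: a 1.0-fold lower number from compound 1 to compound 2 (0.02 log units; within the scatter). There, acetoxy takes the place of hydrogen on a saturated ring carbon rather than on an oxygen, and the step stays within the scatter. On that evidence, no step beyond the scatter is expected in this assay, and no direction can be favoured with confidence. The estimated step is a 1.3-fold lower number from compound 1 to compound 3 (0.10 log units; within the scatter). Compound 3 is expected at 20000 nM, with an estimated range of 9000 nM to 45000 nM.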

Compound 3, half-maximal inhibitory concentration: 84000 nM
Estimate against measurement, compound 3: 4.2-fold (0.62 log units) below, and the stated range ends below it.
By their numbers in this assay, from the lowest: compounds 2 and 1 (each within the scatter of the next); then compound 3.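

In this assay the change of hydroxy to acetoxy on the side chain gives a 3.4-fold higher number from compound 1 to compound 3 (0.53 log units; beyond the scatter) and so lies beyond the scatter, which means weaker inhibition for the acetylated compound. Going by these compounds alone, the earlier step, with acetoxy on a saturated ring carbon, gave only a 1.0-fold lower number from compound 1 to compound 2 (0.02 log units; within the scatter) and stayed within the scatter, so the oxygen on this saturated carbon is the first place in the set where a change moves the number. Nothing measured here explains the rise.

From the compounds shown here alone, whether the step comes from losing the hydroxy hydrogen or from the added acetyl stays open, as does how a methoxy group, an amine or a carboxylic acid would read at this place. Also open, going by these compounds, is whether acetyl on the same oxygen of compound 2 would give a step of similar size.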